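The source may report more compounds than this note shows. Statements on the series, on what has been measured and on what is new or still open speak of the compounds shown alone.

In an ADME assay on HepG2 cells (Homo sapiens) for cytotoxicity, read by CellTiter-Glo and resazurin assay, with a stated time of 72 h (a lower number here means that less compound is needed, a higher number that more compound is needed for the effect), compound 1 `CCOC(=O)CCCCCOc1cccc(CN(C(=O)c2ccc(-c3cccc(OCC(C)C)c3)cc2)C(C)C)c1` gives > 26000 nM, which is a limit of the assay rather than a number. In this assay compound 2 `CCOC(=O)CCCCCOc1cccc(CN(C(=O)c2ccc(-c3ccoc3)cc2)C(C)C)c1` gives > 26000 nM, again a limit. In this assay compound 3 `CCOC(=O)CCCCCOc1cccc(CN(C(=O)c2ccc(-c3ccc(C(C)=O)s3)cc2)C(C)C)c1` gives > 26000 nM, also a limit.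

Within the data shown here, compound 3 therefore stands where everything measured here stands, at the limit of > 26000 nM in this assay, at which 3 of the 3 values shown sit, so no compound can be told apart from another. The three swaps at this position between measured compounds gave a step that the two limits leave unreadable from compound 1 to compound 2, a step that the two limits leave unreadable from compound 1 to compound 3 and a step that the two limits leave unreadable from compound 2 to compound 3; none of them has a readable size.

Compound 4 `CCOC(=O)CCCCCOc1cccc(CN(C(=O)c2ccc(-c3cccc(Br)c3)cc2)C(C)C)c1` differs from compound 3 by 3-bromophenyl in place of 5-acetylthiophen-2-yl on an aromatic carbon. The measured steps that bear on this change are exactly these three swaps of the group at the same aromatic carbon, and each of them was hidden by the limits. The step from compound 3 to compound 4 is therefore expected to be a step that the limit leaves unreadable from compound 3 to compound 4, with no direction that can be read. Compound 4 is estimated at 40000 nM, within 15000 nM to 120000 nM, and most probably the assay will again report only a limit.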

Compound 4, half-maximal effective concentration: > 26000 nM
Compound 4: a limit, no number; the forecaster's own chance of this, stated with the estimate: 85%; the middle value lies beyond the limit too.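

Compound 4, like compounds 1, 2 and 3, gives only a limit of the assay, so no step among these four compounds can be read: the limit of > 26000 nM in this assay, at which 4 of the 4 values shown sit.

What the compounds shown leave open is whether any change at this aromatic carbon alters the value in this assay, since none has yet given a number.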